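From sulfonyl to benzylsulfanyl at the assay limit

The source may hold more compounds than are shown below. What is called first, only, known or untested is meant among the compounds shown, and "the series" means these compounds.

In a functional assay on DU-145 cells (Homo sapiens) for inhibition, read by trypan blue exclusion, with a stated time of 96 h (a lower number here means a stronger inhibitor of growth, a higher number a weaker inhibitor of growth), compound 1 `COc1cc(OC)c(/C=C(\C(=O)c2ccc(Br)cc2)S(=O)(=O)c2ccc(Br)cc2)c(OC)c1` gives > 100000 nM, which is a limit. Compound 2 `COc1cc(OC)c(/C=C(\C(=O)c2ccc(Br)cc2)S(=O)(=O)c2ccc(C)cc2)c(OC)c1` gives > 100000 nM, also a limit, so it stands without a number, at the limit of > 100000 nM in this assay, at which 2 of the 2 values shown sit. Compound 3 `COc1cc(OC)c(/C=C(/SCc2ccc(F)cc2)C(=O)c2ccc(Br)cc2)c(OC)c1` differs from it by (4-fluorobenzyl)sulfanyl in place of (4-methylphenyl)sulfonyl on a double-bonded chain carbon bound to a carbonyl carbon and a double-bonded chain carbon, with (4-fluorobenzyl)sulfanyl in place of (4-methylphenyl)sulfonyl on a double-bonded chain carbon bound to a carbonyl carbon and a double-bonded chain carbon. Going by the values given here, the only measured step is a step that the two limits leave unreadable from compound 1 to compound 2, and it offers no size to carry over. The expected change is therefore toward stronger inhibition, with its size only loosely bounded, as an at least 20-fold lower number from compound 2 to compound 3 (1.30 log units; beyond the scatter). For compound 3 the estimate is 5000 nM, with an expected range of 300 nM to 80000 nM.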

Compound 3, concentration for 50% growth inhibition: 1000 nM
For compound 3 the middle estimate is 5.0-fold (0.70 log units) above the measured one, and the stated range covers the measured number.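

At the double-bonded chain carbon bound to a carbonyl carbon and a double-bonded chain carbon, one exchange brings this assay to a readable number. (4-Fluorobenzyl)sulfanyl in place of (4-methylphenyl)sulfonyl gives an at least 100-fold lower number from compound 2 to compound 3 (2.00 log units; beyond the scatter), and in place of (4-bromophenyl)sulfonyl it gives an at least 100-fold lower number from compound 1 to compound 3 (2.00 log units; beyond the scatter). Both sizes are only lower bounds because the two sulfonyl compounds stop at the assay limit: the limit of > 100000 nM in this assay, at which 2 of the 3 values shown sit.

The compounds shown leave open which part of the exchange carries the step, the sulfur's state, the added carbon or the fluorine. As far as these compounds go, whether an unsubstituted benzylsulfanyl or an amine at this carbon would read alike also remains open.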